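Switching the ring-nitrogen substituent from propyl to cyclobutyl

This account rests on a few compounds, and the source may have more. Where it says the series, first, only, none or still open, it means among the compounds named here.

Measured compounds:
- compound 1 `CCCn1c(-c2ccc(OCc3c(-c4c(Cl)cccc4Cl)noc3C(C)C)cc2)nc2ccc(C(=O)O)cc21`: 1400 nM
- compound 2 `CC(C)c1onc(-c2c(Cl)cccc2Cl)c1COc1ccc(-c2nc3ccc(C(=O)O)cc3n2CC2CCCCC2)c(Cl)c1`: 160 nM
- compound 3 `CCC(CC)n1c(-c2ccc(OCc3c(-c4c(Cl)cccc4Cl)noc3C(C)C)cc2Cl)nc2ccc(C(=O)O)cc21`: 1010 nM

In an assay on HEK-293T cells for antagonist activity at vitamin D3 receptor (Homo sapiens), read by a luciferase reporter, with a stated time of 24 h (a higher number here means a weaker inhibitor, a lower number a stronger inhibitor), compound 1 gives the highest of the three numbers; its nearest neighbour is compound 3, within the scatter, while compound 2 sits well beyond it. Compound 4 `CC(C)c1onc(-c2c(Cl)cccc2Cl)c1COc1ccc(-c2nc3ccc(C(=O)O)cc3n2C2CCC2)cc1` has not been measured; it differs from compound 1 by cyclobutyl in place of propyl on an aromatic nitrogen. For the measured compounds named here, the only measured step at that aromatic nitrogen is a 6.3-fold higher number from compound 2 to compound 3 (0.80 log units; beyond the scatter), so substituents there can move the number modestly. Going by the values given here, since no step matches cyclobutyl for propyl, compound 4 is expected to stay near compound 1, estimated at 1000 nM (range 300 nM to 3000 nM), which is the expected step of a 1.4-fold lower number from compound 1 to compound 4 (0.15 log units; within the scatter).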

Compound 4, half-maximal inhibitory concentration: 1100 nM
Compound 4: the middle estimate sits 1.1-fold (0.04 log units) below what was measured; low and high end bracket the measured number.
By their numbers in this assay, from the lowest: compound 2; then compounds 3, 4 and 1 (each within the scatter of the next).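

In this assay, a 1.3-fold lower number from compound 1 to compound 4 (0.10 log units; within the scatter) shows that replacing propyl with cyclobutyl on the aromatic nitrogen leaves the number within the scatter, even though the new group adds a four-membered ring. The position therefore accepts a change that does not move the number, alongside the earlier 6.3-fold higher number from compound 2 to compound 3 (0.80 log units; beyond the scatter), which did move it. No evidence here accounts for this result.

Going by these compounds, it remains open whether a ring carrying an amine, or a longer chain such as hexyl, would read the same at this nitrogen. Also open, on these data alone, is how cyclohexylmethyl would read on the core of compound 1, which lacks the additional ring chlorine of compound 2.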